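Hydroxamic acid series: removing trifluoromethyl from the benzyl cap

This account rests on a few compounds, and the source may have more. Where it says the series, first, only, none or still open, it means among the compounds named here.

Measured so far:
compound 1 `O=C(CCC1=CCN(Cc2ccc(C(F)(F)F)cc2)C1=O)NO` — 4290 nM
compound 2 `O=C(CCC1=CCN(Cc2cccc(C(F)(F)F)c2)C1=O)NO` — 670 nM
compound 3 `COc1cccc(CCCN2CC=C(CCC(=O)NO)C2=O)c1` — 2480 nM

In a functional assay on ACHN cells (Homo sapiens) for antiproliferative activity (on this read-out lower numbers stand for stronger inhibition of growth and higher numbers for weaker inhibition of growth), compound 1 gives the highest of the three numbers. Compound 3 gives 2480 nM, a gap within the scatter, whereas compound 2 gives 670 nM, a gap beyond the scatter.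

Compound 4 `O=C(CCC1=CCN(Cc2ccccc2)C1=O)NO` is not yet measured. Relative to compound 1 the change is hydrogen in place of trifluoromethyl on an aromatic carbon, on an aromatic carbon of the six-membered aromatic ring of carbon only.

Within the data shown here, no measured pair isolates this change, so the expected step from compound 1 to compound 4 is set as none beyond the scatter, with wide uncertainty: a 1.1-fold lower number from compound 1 to compound 4 (0.03 log units; within the scatter). Compound 4 is thus estimated at 4000 nM, within 1500 nM to 12000 nM.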

Compound 4, concentration for 50% growth inhibition: 1080 nM
Estimate against measurement, compound 4: 3.7-fold (0.57 log units) above; measured number below the stated range.
By their numbers in this assay, from the lowest: compounds 2 and 4 (each within the scatter of the next); then compounds 3 and 1 (each within the scatter of the next).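

In this assay, among these compounds, hydrogen in place of trifluoromethyl on an aromatic carbon para to a large group gives a 4.0-fold lower number from compound 1 to compound 4 (0.60 log units; beyond the scatter), the first isolated evidence that trifluoromethyl at this place weakens growth inhibition relative to hydrogen. The same exchange at the trifluoromethyl placing of compound 2 gives a 1.6-fold higher number from compound 2 to compound 4 (0.21 log units; within the scatter), so there the two substituents cannot be told apart. Nothing measured here bears on the reason for these steps. On these data alone, whether fluorine, methoxy, an amine or a carboxylic acid at this place would match hydrogen stays open. Also open, as far as these compounds go, is whether these steps hold on other caps.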